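Adding a Methyl to the Core of Compound 3

The source may hold more compounds than are shown below. What is called first, only, known or untested is meant among the compounds shown, and "the series" means these compounds.

Compound 1, `O=C(O)CCc1ccc(C#Cc2ccnc(F)c2)cc1`: 98%
Compound 2, `Cc1cnc(F)cc1C#Cc1ccc(CCC(=O)O)cc1`: 99%
Compound 3, `O=C(O)CCc1ccc(C#Cc2ccnc(Cl)n2)cc1`: 131%

All three measured compounds were tested in an in vitro functional assay on 1321-N1 cells for agonist activity at Free fatty acid receptor 1 (Homo sapiens), read by fluorescence, spectrophotometry and calcium flux; on this read-out lower numbers stand for smaller maximal responses and higher numbers for larger maximal responses. Compound 1 and compound 2 differ in one place: methyl in place of hydrogen on an aromatic carbon. This change gave a number 1 percentage points higher from compound 1 to compound 2 (within the scatter), so the two values lie within the scatter of each other and nothing can be said about their order.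

Compound 3 carries a different core, and the difference between the two cores is not broken down here. In this assay compound 3 gives the highest value of the three; its steps to compound 2 and to compound 1 are both beyond the scatter.

Compound 4, `Cc1cnc(Cl)nc1C#Cc1ccc(CCC(=O)O)cc1`, has not yet been measured. It differs from compound 3 in one place: methyl in place of hydrogen on an aromatic carbon. Within the data shown here, the change is the same kind of change as the one from compound 1 to compound 2, but the surroundings differ: in compound 4 the methyl enters a six-membered aromatic ring with 2 nitrogen and sits para to a chloro group, whereas in compound 2 the ring holds 1 nitrogen and the methyl sits para to a fluoro group.

Because the methyl gave a number 1 percentage points higher from compound 1 to compound 2 (within the scatter), compound 4 is expected to stay close to compound 3, with an estimated step of a number 1 percentage points higher from compound 3 to compound 4 (within the scatter). Compound 4 is therefore estimated to give 132% in this assay, expected to fall between 115% and 150%.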

Compound 4, largest response reached (reported as efficacy), in percent of the reference or control that the assay uses: 121%
Estimate against measurement, compound 4: 11 percentage points above; the range from low to high includes it.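

In this assay, methyl in place of hydrogen on the aromatic carbon of the core of compound 3 gave a number 10 percentage points lower from compound 3 to compound 4 (within the scatter), so compound 3 and compound 4 cannot be placed in any order. On the evidence of these two pairs, the change reads the same on both cores, with neither step separable from the scatter and no difference between the two steps that could be told apart from it: the same change on two cores in this assay, a number 1 percentage points higher (within the scatter) from compound 1 to compound 2 and a number 10 percentage points lower (within the scatter) from compound 3 to compound 4, 11 percentage points apart, within the scatter of two such steps

This shows that, in these two pairs, the methyl left the maximal response within the scatter, whether it entered the ring with 1 nitrogen and a fluoro group or the ring with 2 nitrogen and a chloro group, but it does not show that the two steps are truly equal, since a small real effect on either core could lie hidden in the scatter, and two pairs set no rule for other cores in the series.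

The compounds shown leave open whether an ethyl or a methoxy group on the same carbon would behave as the methyl does. They also leave open how the methyl would read with a bromo group or an amine in place of the chloro group.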